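Swapping the Sulfur Link for Oxygen on the Pendant Phenyl

The compounds below may be only part of what the source reports. "The series", "measured", "known", "first", "only" and "open" are said of these compounds alone.

Of the compounds shown here, two have been tested in a functional assay on HEK293 cells for antagonist activity at proteinase-activated receptor 4 (Homo sapiens), read by FLIPR and calcium flux, with a stated time of 30 min; on this read-out higher numbers stand for weaker inhibition and lower numbers for stronger inhibition. Compound 1 `COc1cc(OCc2cccc(O)c2)c2cc(-c3cn4nc(OC)sc4n3)oc2c1` gives 3.1 nM, and compound 2 `COc1cc(OCc2cccc(Sc3ccccc3)c2)c2cc(-c3cn4nc(OC)sc4n3)oc2c1` gives 0.89 nM. Going by the values given here, replacing the hydroxy of compound 1 with phenylsulfanyl gave a 3.5-fold lower number from compound 1 to compound 2 (0.54 log units; beyond the scatter), so compound 2 stands with the lowest number of the two, and compound 1 is its only neighbour.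

Compound 3 `COc1cc(OCc2cccc(Oc3ccccc3)c2)c2cc(-c3cn4nc(OC)sc4n3)oc2c1` has not yet been measured. It differs from compound 2 by phenoxy in place of phenylsulfanyl on an aromatic carbon. Among the compounds with values here, no measured step exchanges oxygen for sulfur in such a linker, so the only guidance is the step from compound 1 to compound 2, which shows that a phenyl-bearing group at this position is well tolerated. The expectation for compound 3 in this assay is therefore a step of a 1.5-fold higher number from compound 2 to compound 3 (0.16 log units; within the scatter), within the scatter of repeated measurements. Compound 3 is estimated at 1.3 nM, with a range of 0.5 nM to 3.5 nM.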

Compound 3, half-maximal inhibitory concentration: 1.2 nM
Compound 3: the middle estimate sits 1.1-fold (0.03 log units) above what was measured; measured number inside the range.
By their numbers in this assay, from the lowest: compounds 2 and 3 (each within the scatter of the next); then compound 1.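

In this assay phenoxy in place of phenylsulfanyl gives a 1.3-fold higher number from compound 2 to compound 3 (0.13 log units; within the scatter) and so the oxygen link and the sulfur link cannot be told apart at this place on the ring. Phenyl in place of hydrogen on the oxygen gives a 2.6-fold lower number from compound 1 to compound 3 (0.41 log units; beyond the scatter) and so the lower number seen with an added phenyl is not tied to a sulfur link, since it appears with either atom. Nothing measured here explains why the two links read alike.

On these data alone, whether any single-atom link is needed stays open, since a methylene or amine link, or a phenyl joined directly to the ring, would be the next comparison. The compounds shown also leave open how a carboxylic acid or an amine on the outer phenyl would read.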